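The compounds below may be only part of what the source reports. "The series", "measured", "known", "first", "only" and "open" are said of these compounds alone.

Measured so far:
- compound 1 `CCO[C@H]1C[C@@H](c2coc3ccc(Br)cc3c2=O)N(c2ccccc2)O1`: > 60000 nM, a limit of the assay
- compound 2 `Cc1ccc2occ([C@@H]3[C@H]4C(=O)N(c5ccccc5)C(=O)[C@H]4ON3c3ccccc3)c(=O)c2c1`: 11100 nM
- compound 3 `O=c1c([C@@H]2C[C@H](c3ccccc3)ON2c2ccccc2)coc2ccccc12`: > 60000 nM, a limit of the assay

For the measured compounds named here, in a functional assay on PC-3 cells (Homo sapiens) for inhibition, read by sulforhodamine B assay, with a stated time of 48 h (on this read-out higher numbers stand for weaker inhibition and lower numbers for stronger inhibition), compound 2 gives 11100 nM and holds the only numerical value of the three. Compound 1 reaches only > 60000 nM, a limit of the assay. Compound 3 likewise reaches only > 60000 nM, again a limit. Going by the values given here, both sit at the limit of > 60000 nM in this assay, at which 2 of the 3 values shown sit, so no step between measured compounds can be sized.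

Compound 4 `O=C1[C@H]2[C@H](ON(c3ccccc3)[C@@H]2c2coc3ccc(F)cc3c2=O)C(=O)N1c1ccccc1` differs from compound 2 by fluoro in place of methyl on an aromatic carbon. Among the compounds with values here, with no measured step to lean on, the change is expected to stay within the scatter, with no clear direction: the step of a 1.1-fold higher number from compound 2 to compound 4 (0.03 log units; within the scatter) is the expectation. Compound 4 is estimated at 12000 nM, in the range 4000 nM to 40000 nM.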

Compound 4, half-maximal inhibitory concentration: > 60000 nM
Compound 4: no number, only a limit; the forecaster's own chance of this, stated with the estimate: 20%; at least 5.0-fold (0.69 log units) between middle value and limit.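

On this aromatic carbon of the core of compound 2, the change is not silent: in this assay, fluoro in place of methyl gives an at least 5.4-fold higher number from compound 2 to compound 4 (0.73 log units; beyond the scatter). Compound 4 gives > 60000 nM, which is a limit of the assay and not a number. The step therefore has a lower bound only, and the methyl compound remains the only one with a measured value: the limit of > 60000 nM in this assay, at which 3 of the 4 values shown sit.

Open, as far as these compounds go, is how a chloro, a methoxy or an amine on this same carbon would read on the core of compound 2. Also open, from the compounds shown here alone, is whether a longer chain such as ethyl would keep a measurable value.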